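Compound 1 to compound 4: a shorter side chain

The compounds below may be only part of what the source reports. "The series", "measured", "known", "first", "only" and "open" are said of these compounds alone.

Three compounds of the series carry numbers in a functional assay on L1210 cells (Mus musculus) for antiproliferative activity; on this read-out lower numbers stand for lower potency and higher numbers for higher potency (the scale is a negative logarithm). Compound 1 `CN(C)/N=N/c1nc(Cc2ccccc2)[nH]c1C(N)=O` gives 2.89 in this assay. Compound 2 `COC(=O)c1[nH]cnc1/N=N/N(C)C` gives 3.86. Compound 3 `CN(C)/N=N/c1c(Cl)cc(Cl)cc1C(N)=O` gives 3.14. Compound 1 stands lowest of the three numbers; its distance to compound 3 lies within the usual scatter, so no order between those two is claimed, while its distance to compound 2 lies beyond the scatter and compound 2 sits clearly higher.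

Compound 4 `CCCc1nc(/N=N/N(C)C)c(C(N)=O)[nH]1` has not yet been measured. It differs from compound 1 in one place: ethyl in place of phenyl on a saturated chain carbon bound to an aromatic carbon. Everything else of compound 1 is kept. Within the data shown here, no pair among the measured compounds shows this same change, so there is no step to copy; the three measured compounds differ from one another in several places at once and give no clean guide to what ethyl in place of phenyl does here.

Expectation: the step from compound 1 to compound 4 is expected to be about a number 0.11 log units higher from compound 1 to compound 4 (within the scatter), a size within the scatter and without a clear direction. Compound 4 is therefore estimated at 3 in this assay, with a range from 2.4 to 3.6.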

Compound 4, logarithm of the reciprocal of the active concentration, log(1/C): 3.42
Compound 4: the middle estimate sits 0.42 log units below what was measured, and the stated range covers the measured number.
By their numbers in this assay, from the lowest: compounds 1, 3 and 4 (each within the scatter of the next, the first and the last beyond it); then compound 2.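

In this assay, among these compounds, ethyl in place of phenyl on a saturated chain carbon bound to an aromatic carbon gives the first one-place step, a number 0.53 log units higher from compound 1 to compound 4 (beyond the scatter), so this position responds measurably to the group it carries, though the step is modest. The six-membered aromatic ring of compound 1 is not needed to hold the number at this position, since compound 4 carries no ring there and its number does not fall. No measurement at hand accounts for this step, so the data record its size and direction but no cause.

This single step changes two things together: the ring goes, and the group shrinks from 6 heavy atoms to 2, so the compounds shown do not separate the loss of the ring from the loss of size. Cyclohexyl would test the need for aromatic character at this position, while a longer chain such as butyl, or a chain ending in an amine or a carboxylic acid, would show whether the trend extends beyond ethyl.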